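One side group changes on a shared core

The compounds below may be only part of what the source reports. "The series", "measured", "known", "first", "only" and "open" are said of these compounds alone.

In a functional assay on DU-145 cells (Homo sapiens) for antiproliferative activity, read by sulforhodamine B assay, with a stated time of 3 days (a higher number here means a weaker inhibitor of growth, a lower number a stronger inhibitor of growth), compound 1 (`O=C(Nc1ccccn1)c1cccc(Nc2ncc(F)c(Nc3ccc(F)cc3)n2)c1`) gives 15100 nM and compound 2 (`O=C(Nc1cccc(Nc2ncc(F)c(Nc3ccc(F)cc3)n2)c1)c1cnccn1`) gives 26400 nM as its reading. Going by the values given here, these two numbers lie within the scatter of each other, so compound 2 stands level with the only other measured compound. Compound 3 (`O=C(c1cccc(Nc2ncc(F)c(Nc3ccc(F)cc3)n2)c1)N1CCCCC1`) keeps the shared core and carries (piperidin-1-yl)carbonyl in place of ((pyrazin-2-yl)carbonyl)amino on an aromatic carbon is the full count of that difference. Among the compounds with values here, only one measured step bears on this change, namely a 1.7-fold higher number from compound 1 to compound 2 (0.24 log units; within the scatter) and it exchanges the group at the same place. Within the data shown here, no measured compound carries the new group, so this guidance is thin and the range must stay wide. No change beyond the scatter is expected in this assay and the estimated size is a 1.3-fold lower number from compound 2 to compound 3 (0.12 log units; within the scatter) for this swap. For compound 3 the estimated value is 20000 nM with an expected range from 8000 nM to 50000 nM in this reading.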

Compound 3, concentration for 50% growth inhibition: 13000 nM
Estimate against measurement, compound 3: 1.5-fold (0.19 log units) above; the range from low to high includes it.
By their numbers in this assay, from the lowest: compounds 3, 1 and 2 (each within the scatter of the next, the first and the last beyond it).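

In this assay, going by these compounds alone, (piperidin-1-yl)carbonyl in place of ((pyrazin-2-yl)carbonyl)amino gives a 2.0-fold lower number from compound 2 to compound 3 (0.31 log units; beyond the scatter), the first modest step beyond the scatter at this position. The other comparison, a 1.2-fold lower number from compound 1 to compound 3 (0.07 log units; within the scatter), with piperidin-1-yl in place of (pyridin-2-yl)amino on a carbonyl carbon, shows no separation, so among these compounds growth inhibition at this level does not need an aromatic ring in this side group, nor a hydrogen-bond donor, since the entering group has 0 hydrogen-bond donors. Nothing measured here gives a reason for either step.

The compounds shown leave open whether a morpholine ring in place of the piperidine would hold the reading at this level. They also leave open whether a carboxylic acid or an open-chain dimethylamino amide on the same aromatic carbon would move it further.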